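Swapping One Group on a Carbonyl Carbon

This account rests on a few compounds, and the source may have more. Where it says the series, first, only, none or still open, it means among the compounds named here.

Compound 1 `COc1cc(Cl)cc(-c2nn(-c3cccc(NC(=O)Nc4ccc(Cl)c(C(F)(F)F)c4)c3)cc2-c2ccncc2)c1` is the starting point. In a functional assay on NCI-H226 cells (Homo sapiens) for inhibition, read by sulforhodamine B assay, with a stated time of 48 h, tested at 0.1 uM (on this read-out lower numbers stand for a stronger effect and higher numbers for a weaker effect at the one concentration tested), compound 1 gives 96%. Compound 2 `COc1cc(Cl)cc(-c2nn(-c3cccc(NC(=O)Nc4cc(C(F)(F)F)cc(C(F)(F)F)c4)c3)cc2-c2ccncc2)c1`, a close relative, gives 102% in this assay; the two numbers sit within the usual scatter of each other, so neither compound stands apart from the other. Compound 3 `COc1cc(Cl)cc(-c2nn(-c3cccc(NC(=O)c4cccc(C(F)(F)F)c4)c3)cc2-c2ccncc2)c1` has not yet been measured. Its difference from compound 1 is 3-(trifluoromethyl)phenyl in place of (4-chloro-3-(trifluoromethyl)phenyl)amino on a carbonyl carbon. Within the data shown here, no measured pair shows a change of this kind, so the expected step of a number 2 percentage points higher from compound 1 to compound 3 (within the scatter) is none beyond the scatter. Compound 3 is accordingly estimated at 98%, within a range from 85% to 110%.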

Compound 3, a percentage reported as activity, at one concentration (the size of the read-out at that concentration, not a potency): 90%
For compound 3 the middle estimate is 8 percentage points above the measured one; measured number inside the range.
By their numbers in this assay, from the lowest: compounds 3, 1 and 2 (each within the scatter of the next, the first and the last beyond it).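

In this assay, putting 3-(trifluoromethyl)phenyl in place of (4-chloro-3-(trifluoromethyl)phenyl)amino on a carbonyl carbon gives a number 6 percentage points lower from compound 1 to compound 3 (within the scatter). At this one concentration, then, the amino nitrogen with its hydrogen-bond donor and the chlorine can leave together with no change beyond the scatter. Nothing measured on these groups bears on this result. Because both left in one step, the compounds shown cannot separate the nitrogen from the chlorine. From the compounds shown here alone, whether a methyl, a morpholine or a carboxylic acid in this place would move the number beyond the scatter remains open.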